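Swapping a side-chain group on a second core

The source may report more compounds than this note shows. Statements on the series, on what has been measured and on what is new or still open speak of the compounds shown alone.

Four compounds share a design in which a side chain on a saturated chain carbon sits two bonds along the chain from an amide-type nitrogen and a carbonyl carbon, while the core attached to the other end varies. Compound 1 `N=C(N)NCCC[C@H](NC(=O)CN(c1nc(Cl)nc2[nH]cnc12)C1CC1)C(=O)OCc1ccccc1` gives 10.2% in a functional assay on the whole organism (Tail, strain ICR) with Mus musculus as the target, in the tail flick test, with a stated time of 120 min, at a dose of 25 umol/kg by the oral route; on this read-out higher numbers stand for a stronger effect at the one dose given and lower numbers for a weaker effect. Compound 3 `CC(C)C[C@H](NC(=O)CN(c1nc(Cl)nc2[nH]cnc12)C1CC1)C(=O)OCc1ccccc1` carries isopropyl in place of the larger group and gives 8.58% in this assay; the change is a group of 3 heavy atoms (3 carbon; no ring) in place of a group of 6 heavy atoms (3 carbon, 3 nitrogen; no ring), on a saturated chain carbon, two bonds along the chain from an amide-type nitrogen and a carbonyl carbon and it moved the read-out by a number 1.6 percentage points lower from compound 1 to compound 3 (within the scatter). Compound 2 `N=C(N)NCCC[C@H](NC(=O)CN(c1ncnc2c1ncn2C1CCCCO1)C1CC1)C(=O)OCc1ccccc1` has a different core; the difference between the two cores is not broken down here. In this assay compound 2 gives 38.2%, the highest of the three measured numbers.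

Compound 4 `CC(C)C[C@H](NC(=O)CN(c1ncnc2c1ncn2C1CCCCO1)C1CC1)C(=O)OCc1ccccc1` is not yet measured. It differs from compound 2 by a group of 3 heavy atoms (3 carbon; no ring) in place of a group of 6 heavy atoms (3 carbon, 3 nitrogen; no ring), on a saturated chain carbon, two bonds along the chain from an amide-type nitrogen and a carbonyl carbon, the same change that turned compound 1 into compound 3. Because that earlier change gave a number 1.6 percentage points lower from compound 1 to compound 3 (within the scatter), a step of about a number 3.2 percentage points lower from compound 2 to compound 4 (within the scatter) is expected here, so compound 4 is estimated at 35%, likely between 20% and 50%, with the caveat that the change has only been seen once, on a different core.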

Compound 4, a percentage reported as activity, at one dose (the size of the read-out at that dose, not a potency): 12.8%
Compound 4: the middle estimate sits 22.2 percentage points above what was measured, and the stated range ends above it.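

The swap to isopropyl gives a number 25.4 percentage points lower from compound 2 to compound 4 (beyond the scatter), so on this core the larger group cannot be exchanged without a clear loss of effect at the one dose tested. The same change therefore does not carry over from one core to the other with a constant size in this assay, and an estimate borrowed from the first pair would not hold for the second: the same change on two cores in this assay, a number 1.6 percentage points lower (within the scatter) from compound 1 to compound 3 and a number 25.4 percentage points lower (beyond the scatter) from compound 2 to compound 4, 23.8 percentage points apart, beyond the scatter of two such steps. This rests on just two pairs at a single dose and a single time, so it shows that the core matters but not why, nor how the change would behave on any further core.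

As far as these compounds go, it remains open which part of the difference between the two cores governs the size of the step. Also open, from the compounds shown here alone, is how a plain amine, a carboxylic acid or a longer chain would fare at the same place on the chain, on either core.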